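Alpha-ketone series: oxazole replacement and a pyridyl extension

The compounds below may be only part of what the source reports. "The series", "measured", "known", "first", "only" and "open" are said of these compounds alone.

Measured so far:
compound 1, `CCCCCCCC/C=C\CCCCCCC(=O)c1ccccc1`, > 100000 nM
compound 2, `CCCCCCCC/C=C\CCCCCCC(=O)c1ncco1`, 17 nM

Compound 1 carries a phenyl ketone; in an assay on isolated protein for inhibition of Fatty-acid amide hydrolase 1 (Homo sapiens) (on this read-out higher numbers stand for weaker inhibition and lower numbers for stronger inhibition), compound 1 gives only a limit, > 100000 nM, and no number. Compound 2 carries the same chain on a 1,3-oxazol-2-yl ketone and in this assay compound 2 gives 17 nM. Among the compounds with values here, the step of an at least 5800-fold lower number from compound 1 to compound 2 (3.76 log units; beyond the scatter) is the one measured change in the set, and its size rests on (the limit of > 100000 nM in this assay, at which 1 of the 2 values shown sits). Within the data shown here, compound 2 is the only compound with a number in this assay; the other value shown is a limit.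

Compound 3, `CCCCCCCC/C=C\CCCCCCC(=O)c1nc(-c2ccccn2)co1`, differs from compound 2 by pyridin-2-yl in place of hydrogen on an aromatic carbon. No measured step concerns a substituent on the oxazole ring, so nothing shown bears directly on this change; the one measured step concerns the ketone ring itself. The expectation for compound 3 therefore stays close to compound 2 with wide uncertainty, an estimated step of a 2.1-fold lower number from compound 2 to compound 3 (0.33 log units; beyond the scatter). Compound 3 is estimated at 8 nM, in the range 1 nM to 60 nM.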

Compound 3, inhibition constant: 31 nM
Estimate against measurement, compound 3: 3.9-fold (0.59 log units) below; low and high end bracket the measured number.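

Within the data shown here, the earlier compounds spoke only to the ring on the ketone; this is the first reading on a substituent of that ring, on an aromatic carbon next to the ring nitrogen, where in this assay pyridin-2-yl in place of hydrogen gives a 1.8-fold higher number from compound 2 to compound 3 (0.26 log units; within the scatter) and so cannot be told apart from hydrogen. This carbon of the oxazole therefore accepts a six-membered aromatic ring while the number stays in the range set by the unsubstituted oxazole ketone, so the potency gained with the ketone ring survives the extension. Nothing shown speaks to why the added ring is accepted at this carbon.

Going by these compounds, whether the ring nitrogen of the pyridin-2-yl contributes anything stays open: a phenyl at the same carbon would separate it from the ring itself, and a carboxylic acid or an amine there would test how far the acceptance reaches. On these data alone, whether this reading holds with a saturated chain in place of the unsaturated one also stays open.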